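An Isopentyl Chain Replaces the Isopropoxycarbonyl Group

A few compounds are considered here, and "the series" means these few. Any claim that something is new, unique, unknown or untested is made for them only; others in the source may bear on it.

Among the measured compounds shown here, compound 2 `CC(C)OC(=O)CN(c1cccc(Cl)c1)S(=O)(=O)c1cccc(NC(=O)CN(C)C(=O)OCc2ccccc2)c1` gives 240 nM in a functional assay on HEK293 cells for antagonist activity at Voltage-dependent T-type calcium channel subunit alpha-1H (Homo sapiens), read by patch clamp (a higher number here means a weaker inhibitor, a lower number a stronger inhibitor), the lower of the two numbers measured so far. Compound 1 `CC(C)OC(=O)CN(c1cccc(Cl)c1)S(=O)(=O)c1cccc(NC(=O)CCc2ccccc2)c1` gives 540 nM in this assay, and a 2.3-fold lower number from compound 1 to compound 2 (0.35 log units; beyond the scatter). Compound 3 `CC(C)CCCN(c1cccc(Cl)c1)S(=O)(=O)c1cccc(NC(=O)CN(C)C(=O)OCc2ccccc2)c1` alters a different part of the molecule: isopentyl in place of isopropoxycarbonyl on a saturated chain carbon bound to a sulfonamide nitrogen. For the measured compounds named here, the single measured step concerns the amide side chain, not this position, so no measured step bears on the change and its direction is open. For compound 3 the expected step is a 1.3-fold higher number from compound 2 to compound 3 (0.10 log units; within the scatter). The estimated value for compound 3 is 300 nM, expected to fall between 80 nM and 1200 nM.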

Compound 3, half-maximal inhibitory concentration: 180 nM
Estimate against measurement, compound 3: 1.7-fold (0.22 log units) above; the measured number falls inside the stated range.
By their numbers in this assay, from the lowest: compounds 3 and 2 (each within the scatter of the next); then compound 1.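

At this place, on a saturated chain carbon bound to a sulfonamide nitrogen, isopentyl in place of isopropoxycarbonyl gives a 1.3-fold lower number from compound 2 to compound 3 (0.12 log units; within the scatter) in this assay and so leaves the two compounds indistinguishable. The isopropoxycarbonyl group's oxygens and carbonyl are therefore not needed to keep this number, since the all-carbon isopentyl chain, with no hydrogen-bond acceptors, matches it. Nothing available explains why the two groups read alike. On these data alone, whether an amine, a carboxylic acid or a longer chain would be tolerated at this place remains open, as does whether isopentyl behaves the same with the amide side chain of compound 1.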